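From 4-fluorophenyl to 3-chlorophenyl in the series

A few compounds are considered here, and "the series" means these few. Any claim that something is new, unique, unknown or untested is made for them only; others in the source may bear on it.

In a functional assay on NCI-H460 cells (Homo sapiens) for antiproliferative activity, read by MTT assay, with a stated time of 48 h (a lower number here means a stronger inhibitor, a higher number a weaker inhibitor), compound 1 `COc1cccc(-c2nc3cccc(-c4cc(OC)c(OC)c(OC)c4)c3o2)c1` gives (> 25000 nM) which is a limit of the assay and not a number. In this assay compound 2 `COc1cc(-c2cccc3nc(-c4cccc(F)c4)oc23)cc(OC)c1OC` gives (3300 nM) on the same core. In this assay compound 3 `COc1cc(-c2cccc3nc(-c4ccc(F)cc4)oc23)cc(OC)c1OC` gives (8700 nM) which is the higher of the two actual numbers.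

The next change leads to compound 4 `COc1cc(-c2cccc3nc(-c4cccc(Cl)c4)oc23)cc(OC)c1OC` with 3-chlorophenyl in place of 4-fluorophenyl on an aromatic carbon.

The measured step closest to this change is a 2.6-fold higher number from compound 2 to compound 3 (0.42 log units; beyond the scatter) with 4-fluorophenyl in place of 3-fluorophenyl. Compound 4 carries its halogen as a 3-chlorophenyl, in the manner of the 3-fluorophenyl of compound 2, so that step is read here in reverse. The steps of an at least 7.5-fold lower number from compound 1 to compound 2 (0.87 log units; beyond the scatter) and an at least 2.8-fold lower number from compound 1 to compound 3 (0.45 log units; beyond the scatter) both start from a limit and fix no exact size. Among the compounds with values here, no chlorophenyl compound has been measured, so the exchange of halogen rests on no step and widens the range.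

A modest step toward a lower number is therefore expected, similar in size to a 2.6-fold higher number from compound 2 to compound 3 (0.42 log units; beyond the scatter) in the opposite direction. The estimated change is a 2.5-fold lower number from compound 3 to compound 4 (0.40 log units; beyond the scatter) (expected). In this assay the estimate for compound 4 is 3500 nM with a range from 1300 nM to 10000 nM (estimated).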

Compound 4, half-maximal inhibitory concentration: > 25000 nM
Compound 4: a limit, no number; the forecaster's own chance of this, stated with the estimate: 5%; middle value at least 7.1-fold (0.85 log units) away from the limit.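

In this assay compound 4 gives > 25000 nM, which is a limit of the assay and not a number. Within the data shown here, the cleanest comparison is the exchange of halogen alone, an at least 7.5-fold higher number from compound 2 to compound 4 (0.87 log units; beyond the scatter), which shows that on this phenyl ring, held on the aromatic carbon of the five-membered ring, the identity of the halogen matters and not only its place, whereas the earlier compounds had varied only the place of a fluorine; the step of an at least 2.8-fold higher number from compound 3 to compound 4 (0.45 log units; beyond the scatter) changes the halogen and its place together, so it cannot be divided between the two. The step between compound 1 and compound 4 cannot be read, as both sit at the same limit: the limit of > 25000 nM in this assay, at which 2 of the 4 values shown sit.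

Open, from the compounds shown here alone, is how far compound 4 lies past its limit, and whether a chlorophenyl with the chlorine placed as the fluorine of compound 3 would also reach the limit, which would separate the halogen from its place. Also open, going by these compounds, is whether a phenyl ring carrying an amine or a carboxylic acid on this same aromatic carbon would give a number in this assay.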